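From Thiourea to Dichlorophenyl Urea on a Shared Core

A few compounds are considered here, and "the series" means these few. Any claim that something is new, unique, unknown or untested is made for them only; others in the source may bear on it.

Going by the values given here, compound 1 `NC(=O)c1c(NC(=O)c2ccccc2Cl)sc2c1CCN(C(=S)Nc1ccccc1)C2` is one of three compounds measured in a functional assay on MKN-74 cells (Homo sapiens) for antiproliferative activity, with a stated time of 24 h; on this read-out lower numbers stand for stronger inhibition and higher numbers for weaker inhibition. Compound 1 gives 15600 nM, the second highest of the three numbers. Compound 2 `NC(=O)c1c(NC(=O)c2ccccc2Cl)sc2c1CCN(C(=S)Nc1ccccc1C(F)(F)F)C2` gives 1870 nM, and compound 3 `NC(=O)c1c(NC(=O)c2ccccc2Cl)sc2c1CCN(C(=S)Nc1ccccc1-c1ccccc1)C2` gives 25800 nM. The step of an 8.3-fold lower number from compound 1 to compound 2 (0.92 log units; beyond the scatter) is beyond the scatter, whereas the step of a 1.7-fold higher number from compound 1 to compound 3 (0.22 log units; within the scatter) lies within it; between the two substituted compounds the step of a 14-fold higher number from compound 2 to compound 3 (1.14 log units; beyond the scatter) is large.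

Compound 4 `NC(=O)c1c(NC(=O)c2ccccc2Cl)sc2c1CCN(C(=O)Nc1c(Cl)cccc1Cl)C2` differs from compound 1 by a group of 11 heavy atoms (7 carbon, 1 nitrogen, 1 oxygen, 2 chlorine; one six-membered aromatic ring of carbon only) in place of a group of 9 heavy atoms (7 carbon, 1 nitrogen, 1 sulfur; one six-membered aromatic ring of carbon only), on an amine nitrogen in a ring. Among the compounds with values here, none of the measured steps covers this change: the steps from compound 1 to compound 2 and to compound 3 alter the aromatic ring while the thiocarbonyl stays, and no measured pair exchanges the thiocarbonyl for a carbonyl or adds chlorine to the ring. Within the data shown here, those two steps show only that changes on this ring can move the number either way by a modest or small amount. The step of a 1.7-fold lower number from compound 1 to compound 4 (0.24 log units; within the scatter) is therefore expected to be modest at most, with either direction possible. Compound 4 is estimated at 9000 nM, within a range from 2000 nM to 35000 nM.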

Compound 4, half-maximal inhibitory concentration: 24400 nM
Compound 4: the middle estimate sits 2.7-fold (0.43 log units) below what was measured, and the stated range covers the measured number.
By their numbers in this assay, from the lowest: compound 2; then compounds 1, 4 and 3 (each within the scatter of the next).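

In this assay the step of a 1.6-fold higher number from compound 1 to compound 4 (0.19 log units; within the scatter) stays within the scatter, so no difference can be read between the two groups on the amine nitrogen in the ring. The earlier compounds shown here varied only the aromatic ring while the thiocarbonyl stayed; this pair shows that (2,6-dichlorophenyl)carbamoyl, which brings a carbonyl and two chlorines together, is compatible with a number of the same order as compound 1. No measured information bears on this result, and it offers no explanation of the agreement between the two compounds.

The carbonyl and the two chlorines enter together, so their separate contributions remain unresolved. Also open, going by these compounds, are whether the trifluoromethyl group would keep its effect with a carbonyl in place of the thiocarbonyl, and how an amine or a carboxylic acid on the aromatic ring would behave.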